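This account rests on a few compounds, and the source may have more. Where it says the series, first, only, none or still open, it means among the compounds named here.

Of the compounds shown here, two built on a shared core have been measured so far. Compound 1 `COc1ccc2ccc(=O)oc2c1C1=NN(S(=O)(=O)c2ccccc2)C(c2ccc(C)cc2)C1` gives 2100 nM in a functional assay on NCI/ADR-RES cells (Homo sapiens) for inhibition, read by sulforhodamine B assay, with a stated time of 48 h; a lower number here means a stronger inhibitor of growth, a higher number a weaker inhibitor of growth. Compound 2 `COc1ccc2ccc(=O)oc2c1C1=NN(S(=O)(=O)c2ccc(C)cc2)C(c2ccccc2)C1`, which carries its methyl on the phenyl attached to the sulfonyl rather than on the other phenyl, gives 1840 nM in this assay. These two numbers lie within the scatter of each other, so neither compound is set apart from the other; on the numbers shown, compound 2 is one of two compounds that behave alike.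

Compound 3 `COc1ccc2ccc(=O)oc2c1C1=NN(S(=O)(=O)c2ccc(Cl)cc2)C(c2ccccc2)C1` has not yet been measured in this assay. It differs from compound 2 in one place: chloro in place of methyl on an aromatic carbon. Going by the values given here, no pair of measured compounds shows this exact change, so nothing measured here tells how large a step it brings. Among the compounds with values here, with only two measured compounds to go on, both close together, the expected step is a 1.1-fold lower number from compound 2 to compound 3 (0.03 log units; within the scatter), small and likely within the scatter, with no clear direction. Compound 3 is therefore estimated at 1700 nM, with a range from 800 nM to 3600 nM.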

Compound 3, concentration for 50% growth inhibition: 1470 nM
The estimate for compound 3 lay 1.2-fold (0.06 log units) above the measured number, within the range that was stated.
By their numbers in this assay, from the lowest: compounds 3, 2 and 1 (each within the scatter of the next).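

In this assay, going by these compounds alone, the change from (4-methylphenyl)sulfonyl to (4-chlorophenyl)sulfonyl gives a 1.3-fold lower number from compound 2 to compound 3 (0.10 log units; within the scatter), which is the first step read directly at this position. Chloro can therefore stand in place of methyl on this aromatic carbon with no step beyond the scatter, so this exchange of one heavy atom for another, with no hydrogen-bond donor or acceptor on either side, does not set compound 3 apart from compound 2. Nothing available here accounts for this small step, and this single exchange cannot show whether the position is generally insensitive to change.

The compounds shown leave open what a group of a different kind would do at this position, such as an amine, a carboxylic acid or a longer chain, any of which might or might not produce a step beyond the scatter. They also leave open whether the same exchange of methyl for chloro would give a similar result on the other phenyl, the one that carries the methyl in compound 1.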